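From Ethyl to Benzyl on the Shared Core

The compounds below may be only part of what the source reports. "The series", "measured", "known", "first", "only" and "open" are said of these compounds alone.

Compound 3 `CCn1c(=O)n(C2OC(CO)[C@@H](O)[C@H]2O)c2nc(N)nc(O)c21` gives 15 uM in a functional assay (B cells) with Mus musculus as the target (on this read-out lower numbers stand for an effect already at smaller amounts and higher numbers for an effect only at larger amounts of compound), the highest number among the three measured compounds. Compound 2 `Nc1nc(O)c2c(n1)n(C1OC(CO)[C@@H](O)[C@H]1O)c(=O)n2Cc1ccc(OCc2ccccc2)cc1` gives 8 uM, which lies within the scatter of that number, while compound 1 `N#Cc1cccc(Cn2c(=O)n(C3OC(CO)[C@@H](O)[C@H]3O)c3nc(N)nc(O)c32)c1` gives 3 uM, a clearly lower number. The unmeasured compound 4 `Nc1nc(O)c2c(n1)n(C1OC(CO)[C@@H](O)[C@H]1O)c(=O)n2Cc1ccccc1` differs from compound 3 by phenyl in place of methyl on a saturated chain carbon bound to an aromatic nitrogen. Going by the values given here, one measured step bears on this change: a 5.0-fold higher number from compound 1 to compound 3 (0.70 log units; beyond the scatter). Compound 4 carries a plain phenyl rather than the 3-cyanophenyl of compound 1, so the reverse of that step is the nearest guide, though the two aryl groups are not identical. For compound 4 a lower number is therefore expected, by a 3.0-fold lower number from compound 3 to compound 4 (0.48 log units; beyond the scatter). Compound 4 is estimated at 5 uM, within a range from 2 uM to 15 uM.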

Compound 4, concentration for half-maximal effect: 6 uM
Estimate against measurement, compound 4: 1.2-fold (0.08 log units) below, within the range that was stated.
By their numbers in this assay, from the lowest: compounds 1, 4, 2 and 3 (each within the scatter of the next, the first and the last beyond it).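

The plain phenyl alone is enough to shift the number at this position, giving a 2.5-fold lower number from compound 3 to compound 4 (0.40 log units; beyond the scatter) in this assay with nothing further on the ring. Substituents on that ring add nothing that can be told apart here. Taking off the cyano group gives a 2.0-fold higher number from compound 1 to compound 4 (0.30 log units; within the scatter) and taking off the benzyloxy group gives a 1.3-fold lower number from compound 2 to compound 4 (0.12 log units; within the scatter) and both steps lie within the scatter.

On these data alone, whether an amine on the ring or a longer chain such as phenylpropyl would change the number remains open. Nothing here shows why the phenyl lowers the number.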